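A Stereochemical Variant of Compound 2

The source may hold more compounds than are shown below. What is called first, only, known or untested is meant among the compounds shown, and "the series" means these compounds.

Compound 1 `CCC/C=C1\OC(=O)C2=C1CC[C@H]1[C@@H]2[C@@]2(OC(=O)C3=C2CCC=C3)[C@H]1CCC` and compound 2 `CCCC[C@]12O[C@@]34CCCC=C3C(=O)O[C@]43[C@@H](CCC)[C@@H]4C=C(C(=O)N1[C@H](C)c1ccccc1)[C@@]32CC4` have both been tested in a functional assay on SK-LU-1 cells (Homo sapiens) for inhibition, read by sulforhodamine B assay, with a stated time of 48 h; a higher number here means a weaker inhibitor, a lower number a stronger inhibitor. In this assay compound 1 gives 13200 nM. In this assay compound 2 gives 4100 nM, the lower of the two numbers, and the gap to compound 1 lies beyond the usual scatter. Among the compounds with values here, no pair of measured compounds differs in only one place, so no single step has been read yet.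

Compound 3 `CCCC[C@]12O[C@@]34CCCC=C3C(=O)O[C@]43[C@@H](CCC)[C@H]4C=C(C(=O)N1[C@@H](C)c1ccccc1)[C@@]32CC4` is next in line for this assay. It relates to compound 2 as follows: the two compounds have the same atoms and bonds and differ only in configuration as drawn: 2 of 7 stereo elements differ; a stereocentre at a saturated ring carbon is drawn S in compound 2 and R in compound 3; a stereocentre at a saturated chain carbon is drawn R in compound 2 and S in compound 3. Within the data shown here, nothing measured so far shows how such a change in configuration plays out in this assay, so the direction is open. For compound 3 the expected step is a 1.5-fold higher number from compound 2 to compound 3 (0.17 log units; within the scatter), with room for a shift in either direction. Compound 3 is estimated at 6000 nM, within a range of 2000 nM to 18000 nM.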

Compound 3, half-maximal inhibitory concentration: 4300 nM
Compound 3: middle estimate off by 1.4-fold (0.14 log units), on the high side; low and high end bracket the measured number.
By their numbers in this assay, from the lowest: compounds 2 and 3 (each within the scatter of the next); then compound 1.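

In this assay, the configuration changes at a saturated ring carbon and at a saturated chain carbon together, and this gives a 1.0-fold higher number from compound 2 to compound 3 (0.02 log units; within the scatter). The two drawn forms therefore cannot be told apart in this assay, and no preference for either arrangement of these two stereocentres can be read from the pair. Within the data shown here, this is the first step that can be read at all, and it tests configuration alone: the fact that compounds 2 and 3 differ only in the configuration as drawn.

From the compounds shown here alone, the two stereocentres change together in this pair, so what each would do on its own remains open, as does the behaviour of the other five stereo elements. Also open, going by these compounds, is how the number would respond to a new group on the shared core, such as an amine or a carboxylic acid.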